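The source may report more compounds than this note shows. Statements on the series, on what has been measured and on what is new or still open speak of the compounds shown alone.

Going by the values given here, compound 2 `Cc1cccc(-c2nnc(-n3[se]c4ccccc4c3=O)s2)c1` stands lowest of the two numbers measured so far in a functional assay on MCF7 cells (Homo sapiens) for antiproliferative activity, read by CCK-8 assay, with a stated time of 48 h; a higher number here means a weaker inhibitor, a lower number a stronger inhibitor: compound 2 gives 19900 nM, whereas compound 1 `O=c1c2ccccc2[se]n1-c1nnc(-c2ccc(Br)cc2)s1` gives 43300 nM. Among the compounds with values here, the single measured step, a 2.2-fold lower number from compound 1 to compound 2 (0.34 log units; beyond the scatter), put 3-methylphenyl in place of 4-bromophenyl on an aromatic carbon, a change of the group itself rather than of where the methyl sits. Compound 3 `Cc1ccc(-c2nnc(-n3[se]c4ccccc4c3=O)s2)cc1` differs from compound 2 by 4-methylphenyl in place of 3-methylphenyl on an aromatic carbon. Within the data shown here, no measured step compares 3-methylphenyl with 4-methylphenyl, so the one step known bears only loosely on this change; it shows that the aryl group matters, but not whether moving the methyl will matter. Among the measured compounds shown here, with the same atoms joined differently and no direct precedent, the step from compound 2 to compound 3 is expected to be none beyond the scatter, estimated as a 1.0-fold higher number from compound 2 to compound 3 (0.00 log units; within the scatter). For compound 3 the expected value in this assay is therefore 20000 nM, with an estimated range from 8000 nM to 50000 nM.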

Compound 3, half-maximal inhibitory concentration: 18700 nM
Compound 3: middle estimate off by 1.1-fold (0.03 log units), on the high side, and the stated range covers the measured number.
By their numbers in this assay, from the lowest: compounds 3 and 2 (each within the scatter of the next); then compound 1.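

In this assay, the change from 3-methylphenyl to 4-methylphenyl gives a 1.1-fold lower number from compound 2 to compound 3 (0.03 log units; within the scatter) and so, for these two compounds, where the methyl sits on the phenyl ring makes no difference that this assay can resolve. The other new step isolates what the earlier comparison could not, since that one changed both the group and its place on the phenyl ring, whereas this one swaps only the group: methyl in place of bromo gives a 2.3-fold lower number from compound 1 to compound 3 (0.36 log units; beyond the scatter) and shows that the group itself separates compound 1 from compound 3, though only modestly. Nothing available explains either result.

The compounds shown do not say whether the methyl contributes anything in its own right, a question that the plain phenyl group would address, nor whether bromo gives the same number in the 3-substituted arrangement as in compound 1. They also leave open how groups of a different kind on the phenyl ring, such as an amine, a methoxy group or a carboxylic acid, would fare in this assay against the modest numbers seen so far.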